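Replacing naphthalen-2-yl with 4-methoxyphenyl on a shared core

A few compounds are considered here, and "the series" means these few. Any claim that something is new, unique, unknown or untested is made for them only; others in the source may bear on it.

Compound 1 `O=C(Nc1cccc(Cl)c1)N1CCN(c2nccc(Oc3cc(Cl)cc(Cl)c3)n2)CC1` gives 7900 nM
Compound 2 `O=C(Nc1ccc2ccccc2c1)N1CCN(c2nccc(Oc3cc(Cl)cc(Cl)c3)n2)CC1` gives 46800 nM

In a functional assay on MDA-MB-231 cells (Homo sapiens) for antiproliferative activity, read by MTT assay, with a stated time of 24 h (on this read-out lower numbers stand for stronger inhibition and higher numbers for weaker inhibition), compound 2 stands highest of the two measured compounds, with 46800 nM as its value. Compound 3 `COc1ccc(NC(=O)N2CCN(c3nccc(Oc4cc(Cl)cc(Cl)c4)n3)CC2)cc1` carries 4-methoxyphenyl in place of naphthalen-2-yl on an amide-type nitrogen. Going by the values given here, the one measured step bearing on this is modest: a 5.9-fold higher number from compound 1 to compound 2 (0.77 log units; beyond the scatter), with naphthalen-2-yl replacing 3-chlorophenyl. Among the compounds with values here, compound 3, like compound 1, has a substituted phenyl group there, so a step of similar size toward a lower number is expected in this assay, though no measured compound carries 4-methoxyphenyl. The expected step is a 3.9-fold lower number from compound 2 to compound 3 (0.59 log units; beyond the scatter). For compound 3 the estimated value is 12000 nM, with an expected range from 4000 nM to 36000 nM.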

Compound 3, half-maximal inhibitory concentration: 16400 nM
Compound 3: the middle estimate sits 1.4-fold (0.14 log units) below what was measured, and the stated range covers the measured number.
By their numbers in this assay, from the lowest: compound 1; then compound 3; then compound 2.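

In this assay, placing 4-methoxyphenyl on the amide-type nitrogen in place of naphthalen-2-yl gives a 2.9-fold lower number from compound 2 to compound 3 (0.46 log units; beyond the scatter). Yet 4-methoxyphenyl does not match 3-chlorophenyl, giving a 2.1-fold higher number from compound 1 to compound 3 (0.32 log units; beyond the scatter). These two groups with a single ring differ beyond the scatter, so among these three compounds, the number of rings alone does not set the value.

Where an unsubstituted phenyl or a benzyl group would fall in this order remains open. Nothing available explains the order of these three compounds.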